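This account rests on a few compounds, and the source may have more. Where it says the series, first, only, none or still open, it means among the compounds named here.

In an ADME assay on microsomes from liver (Rattus norvegicus) for metabolic stability, with a stated time of 10 min, tested at 0.5 uM (a higher number here means that more of the compound is left, a lower number that less of the compound is left), compound 1 `CCc1noc(C)c1[C@@H]1C[C@@](C)(c2ccc(F)cc2F)N=C(N)S1` gives 59%. Going by the values given here, its only measured neighbour, compound 2 `CCc1noc(CC)c1[C@@H]1C[C@@](C)(c2ccc(F)cc2F)N=C(N)S1`, gives 67%. The two results cannot be told apart, as the step is a number 8 percentage points higher from compound 1 to compound 2 (within the scatter).

The unmeasured compound 3 `Cc1nocc1[C@@H]1C[C@@](C)(c2ccc(F)cc2F)N=C(N)S1` keeps the core of compound 1 and differs in one group: 3-methyl-1,2-oxazol-4-yl in place of 3-ethyl-5-methyl-1,2-oxazol-4-yl on a saturated ring carbon. Here, 3-methyl-1,2-oxazol-4-yl stands in place of 3-ethyl-5-methyl-1,2-oxazol-4-yl on a saturated ring carbon, next to the ring sulfur.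

Among the compounds with values here, only one measured step bears on this change: a methyl in place of a hydrogen on a saturated chain carbon bound to an aromatic carbon. That step, which is a number 8 percentage points higher from compound 1 to compound 2 (within the scatter), stayed small, so no step beyond the scatter is expected in this assay. This is a weak guide, however. Within the data shown here, no measured compound shows what happens when a group is removed entirely, so the expected range must stay wide. The estimated step is a number 3 percentage points lower from compound 1 to compound 3 (within the scatter). For compound 3 the expected value is 56%, with an estimated range from 36% to 76%.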

Compound 3, percent of the compound remaining: 77%
Compound 3: the middle estimate sits 21 percentage points below what was measured, outside the stated range (above it).
By their numbers in this assay, from the lowest: compounds 1, 2 and 3 (each within the scatter of the next, the first and the last beyond it).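

Trading 3-ethyl-5-methyl-1,2-oxazol-4-yl for the smaller 3-methyl-1,2-oxazol-4-yl on this saturated ring carbon, next to the ring sulfur, gives in this assay a change of a number 18 percentage points higher from compound 1 to compound 3 (beyond the scatter), the first step in this small set that clears the scatter. So the substituents on the 1,2-oxazol-4-yl ring at this position can shift how much compound is left, which the earlier step of a number 8 percentage points higher from compound 1 to compound 2 (within the scatter), being within the scatter, could not show. No supporting evidence is available to explain this shift.

This single change alters the oxazole ring in two ways, shortening the ethyl to a methyl and removing the other methyl, so the compounds shown cannot tell whether one alteration or both together lie behind the step. A 3-ethyl-1,2-oxazol-4-yl group would help separate the two alterations, and an unsubstituted 1,2-oxazol-4-yl group would show whether the remaining methyl matters in this assay on the shared core.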